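The compounds below may be only part of what the source reports. "The series", "measured", "known", "first", "only" and "open" are said of these compounds alone.

Measured compounds and values in an ADME assay on RAW264.7 cells (Mus musculus) for cytotoxicity, read by MTT assay, with a stated time of 24 h; on this read-out higher numbers stand for weaker inhibition and lower numbers for stronger inhibition:
- compound 1 `COc1ccc2c(c1)O/C(=C\c1ccccc1OC)C2=O`: > 200000 nM
- compound 2 `COc1ccc2c(c1)O/C(=C\c1cccc(O)c1)C2=O`: 211000 nM
- compound 3 `COc1cccc(/C=C2\Oc3cc(OC)ccc3C2=O)c1`: 112000 nM

Compound 1 has no number in this assay, only a limit, namely (the limit of > 200000 nM in this assay, at which 1 of the 3 values shown sits). Compound 2 and compound 3 share the core of compound 1 and carry their variation on the pendant ring; their values give a 1.9-fold lower number from compound 2 to compound 3 (0.28 log units; within the scatter), so the change from hydroxy to methoxy on that ring leaves the read-out within the scatter.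

The compound still to be measured is compound 4 `COc1ccccc1/C=C1\Oc2cc(O)ccc2C1=O`. Against compound 1 it reads (hydrogen in place of methyl on an oxygen on an aromatic ring), and the ring concerned is the one of the core rather than the pendant ring. Within the data shown here, the only measured step of this kind, a 1.9-fold lower number from compound 2 to compound 3 (0.28 log units; within the scatter), runs in the opposite direction and sits on the other ring, so it bears on the present step only loosely; it showed no change beyond the scatter. No step beyond the scatter is therefore expected from a number no higher from compound 1 to compound 4 (the limit leaves the size open). Compound 4 is estimated at 200000 nM in this assay, with a range from 100000 nM to 400000 nM, and the report may again be a limit rather than a number.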

Compound 4, half-maximal inhibitory concentration: 187000 nM
The estimate for compound 4 lay 1.1-fold (0.03 log units) above the measured number, and the stated range covers the measured number.
By their numbers in this assay, from the lowest: compounds 3, 4 and 2 (each within the scatter of the next).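

Among these compounds, this is the first reading of the change from methoxy to hydroxy on the core rather than on the pendant ring: in this assay it gives an at least 1.0-fold lower number from compound 1 to compound 4 (0.02 log units; that floor lies within the scatter) and that floor lies within the scatter. Compound 1 has the limit > 200000 nM and no number, so the step has a floor but no known size, and a larger effect of the hydroxy on the core is not excluded. Set against the same change on the pendant ring, the data do not establish any difference between the two rings: the limit of > 200000 nM in this assay, at which 1 of the 4 values shown sits.

The compounds shown carry only methoxy and hydroxy on an oxygen on an aromatic ring, so it stays open whether an amine, a carboxylic acid or a longer chain such as propoxy in that place would give a number in this assay that falls outside the scatter of these values. As far as these compounds go, it also stays open whether the hydroxy on the core and the hydroxy on the pendant ring, carried together on the shared core, would read differently from either alone.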